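The source may hold more compounds than are shown below. What is called first, only, known or untested is meant among the compounds shown, and "the series" means these compounds.

Measured so far in a physicochemical assay for solubility, read by spectrophotometry, in phosphate buffer, with a stated time of 2 h, at pH 7.4; a lower number here means a less soluble compound, a higher number a more soluble compound:

compound 1 `COc1ccc2[nH]c(C(=O)N3CC(=O)N(Cc4ccccc4)[C@@H](COCc4ccccc4)C3)cc2c1`: 8800 nM
compound 2 `COc1ccc2[nH]c(C(=O)N3CC(=O)N(Cc4ccccc4)[C@@H](COC(C)(C)C)C3)cc2c1`: 65500 nM

Compound 2 stands highest of the two numbers in this assay; its nearest neighbour is compound 1, and the step of a 7.4-fold higher number from compound 1 to compound 2 (0.87 log units; beyond the scatter) lies beyond the scatter. Compound 3 `COc1ccc2[nH]c(C(=O)N3CC(=O)N(Cc4ccccc4)[C@@H](CN4CC5CCCCC5C4)C3)cc2c1` is not yet measured. It differs from compound 2 by a group of 9 heavy atoms (8 carbon, 1 nitrogen; one five-membered non-aromatic ring with 1 hetero atom, one six-membered non-aromatic ring of carbon only) in place of a group of 5 heavy atoms (4 carbon, 1 oxygen; no ring), on a saturated chain carbon bound to a saturated ring carbon.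

For the measured compounds named here, the single measured step, a 7.4-fold higher number from compound 1 to compound 2 (0.87 log units; beyond the scatter), exchanges one group on the oxygen for another while the oxygen itself stays; the change to compound 3 removes that oxygen together with the tert-butyl and brings in a ring-bearing group with a nitrogen. Going by the values given here, no measured step bears on this kind of exchange, so the expectation rests on compound 2 alone. Compound 3 is expected to give 65000 nM in this assay. The expected range for compound 3 runs from 15000 nM to 280000 nM. The step of a 1.0-fold lower number from compound 2 to compound 3 (0.00 log units; within the scatter) is thus expected to stay within the scatter.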

Compound 3, solubility: 23800 nM
Compound 3: middle estimate off by 2.7-fold (0.44 log units), on the high side; the range from low to high includes it.
By their numbers in this assay, from the lowest: compound 1; then compound 3; then compound 2.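

In this assay, this position accepts a group with a nitrogen and two rings in place of an ether side chain, with a 2.8-fold lower number from compound 2 to compound 3 (0.44 log units; beyond the scatter) and with a 2.7-fold higher number from compound 1 to compound 3 (0.43 log units; beyond the scatter) in the same series. Both steps are printed as modest and beyond the scatter, so compound 3 sits between the two ethers, and the order at this position no longer depends on the group on the oxygen alone. Nothing on hand gives a reason for this order.

The exchange changes the linking atom, the ring content and the size of the group in one step, and these three changes cannot be separated in the compounds shown. A diethylamino group or a simple piperidine on the same saturated chain carbon would bear on which of them sets the number.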